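Amine-bearing ethers on the shared core: towards compound 4

The source may hold more compounds than are shown below. What is called first, only, known or untested is meant among the compounds shown, and "the series" means these compounds.

compound 1 `Clc1ccc(Oc2ccc3nc(-c4ccc(OCC5CCNCC5)cc4)oc3c2)cc1`: "not active" (no number reported)
compound 2 `CC(C)N1CCC(Oc2ccc(-c3nc4ccc(Oc5ccc(Cl)cc5)cc4o3)cc2)CC1`: 12.7%
compound 3 `CCN1CCC(COc2ccc(-c3nc4ccc(Oc5ccc(Cl)cc5)cc4o3)cc2)CC1`: 2.1%

In an assay on isolated protein for inhibition of advanced glycosylation end product-specific receptor (Homo sapiens), read by FRET, with stated times of 30 min and 1 h, tested at 4 uM (on this read-out higher numbers stand for more inhibition at the one concentration tested (going by the name of the read-out) and lower numbers for less inhibition), compound 2 gives 12.7% and compound 3 gives 2.1%. Compound 1 gives "not active" (no number reported) in this assay with no number attached, so it cannot be ranked. Among the compounds with values here, compound 3 thus holds the lower of the two numbers; the single step leading to it, a number 10.6 percentage points lower from compound 2 to compound 3 (beyond the scatter), came with a change of the amine-bearing group on the same oxygen.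

Compound 4 `CN1CCN(CCCOc2ccc(-c3nc4ccc(Oc5ccc(Cl)cc5)cc4o3)cc2)CC1` extends this variation: 2-(4-methylpiperazin-1-yl)ethyl in place of 1-ethylpiperidin-4-yl on a saturated chain carbon bound to an oxygen on an aromatic ring. Within the data shown here, no measured step covers this exact exchange. Among the measured compounds shown here, the only step on this part of the molecule, a number 10.6 percentage points lower from compound 2 to compound 3 (beyond the scatter), was modest, and all three measured compounds sit at the low end of this assay, one of them without a number. The step of a number 3.9 percentage points higher from compound 3 to compound 4 (within the scatter) is therefore expected to be small, with no direction beyond the scatter, and a result reported only as inactive remains possible. Compound 4 is expected to give 6% in this assay, within -5% to 18%.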

Compound 4, a percentage reported as inhibition, at one concentration (the size of the read-out at that concentration, not a potency): 24.3%
Beside the measured number, compound 4's estimate is 18.3 percentage points below it; measured number outside the range, above it.
By their numbers in this assay, from the lowest: compound 3; then compound 2; then compound 4.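

In this assay, a number 22.2 percentage points higher from compound 3 to compound 4 (beyond the scatter) goes with 2-(4-methylpiperazin-1-yl)ethyl in place of 1-ethylpiperidin-4-yl on a saturated chain carbon bound to an oxygen on an aromatic ring, which shows that changes at this position can also raise the number. Likewise, a number 11.6 percentage points higher from compound 2 to compound 4 (beyond the scatter) goes with 3-(4-methylpiperazin-1-yl)propyl in place of 1-isopropylpiperidin-4-yl, placing compound 4 above both other compounds that have a number, while compound 1 remains unranked. Nothing available bears on the reason for these rises.

Compound 4 differs from compound 3 in both the ring and the chain, so the shown compounds do not separate the contribution of either. A 3-(piperidin-1-yl)propyl group or a 3-morpholinopropyl group on the same oxygen would help to separate them.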